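Aromatic ring for saturated ring on the side-chain carbon

This account rests on a few compounds, and the source may have more. Where it says the series, first, only, none or still open, it means among the compounds named here.

Measured in an ADME assay on HepG2 cells (Homo sapiens) for inhibition, with a stated time of 48 h; on this read-out higher numbers stand for an effect only at larger amounts of compound and lower numbers for an effect already at smaller amounts:
compound 1 `Brc1ccc(Nc2nc(NCc3ccco3)c3ccccc3n2)cc1`: 19000 nM
compound 2 `CC(O)c1ccc(Nc2nc(NCc3ccco3)c3ccccc3n2)cc1`: 12600 nM
compound 3 `NC(=O)c1ccc(Nc2nc(NCC3CCCO3)c3ccccc3n2)cc1`: 34600 nM

Compound 3 carries the highest of the three numbers; its gap to compound 1 lies within the scatter, while its gap to compound 2 lies beyond it. Compound 4 `NC(=O)c1ccc(Nc2nc(NCc3ccco3)c3ccccc3n2)cc1` differs from compound 3 by furan-2-yl in place of oxolan-2-yl on a saturated chain carbon bound to a nitrogen on an aromatic ring. For the measured compounds named here, no measured step touches this position: the only step with a single change, a 1.5-fold lower number from compound 1 to compound 2 (0.18 log units; within the scatter), concerns the other end of the shared core, and compounds 1 and 2 are not paired with compound 3 by one change alone. A step from compound 3 to compound 4 beyond the scatter is therefore not expected in this assay. The estimate for compound 4 is 25000 nM (10000 nM to 60000 nM), meaning a 1.4-fold lower number from compound 3 to compound 4 (0.14 log units; within the scatter).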

Compound 4, half-maximal effective concentration: 20000 nM
Compound 4: the middle estimate sits 1.3-fold (0.10 log units) above what was measured, and the stated range covers the measured number.
By their numbers in this assay, from the lowest: compounds 2, 1, 4 and 3 (each within the scatter of the next, the first and the last beyond it).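

In this assay, furan-2-yl in place of oxolan-2-yl on this saturated chain carbon gives a step within the scatter (a 1.7-fold lower number from compound 3 to compound 4 (0.24 log units; within the scatter)), so exchanging the saturated ring for the aromatic one is not resolved here. With the (furan-2-yl)methyl side chain held, carbamoyl on the aromatic carbon is likewise not separated from 1-hydroxyethyl (a 1.6-fold higher number from compound 2 to compound 4 (0.20 log units; within the scatter)) or bromo (a 1.1-fold higher number from compound 1 to compound 4 (0.02 log units; within the scatter)). No evidence on the cause of these numbers is available.

Open, on these data alone, is whether a longer alkyl chain or a piperidine ring in place of furan-2-yl would give a step beyond the scatter. As far as these compounds go, a carboxylic acid in place of carbamoyl also remains open.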